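The source may hold more compounds than are shown below. What is called first, only, known or untested is meant among the compounds shown, and "the series" means these compounds.

Measured compounds so far:
- compound 1, `O=C(Nc1ccccc1)c1ccc(/N=N\c2c[nH]c3ccccc23)cc1`, gives 147000 nM in a functional assay on MCF7 cells (Homo sapiens) for inhibition, read by MTT assay, with a stated time of 72 h; on this read-out higher numbers stand for weaker inhibition and lower numbers for stronger inhibition.
- compound 2, `Cc1ccc(NC(=O)c2ccc(/N=N\c3c[nH]c4ccccc34)cc2)cc1`, gives 42400 nM in this assay.
- compound 3, `COc1ccccc1NC(=O)c1ccc(/N=N\c2c[nH]c3ccccc23)cc1`, gives 86500 nM in this assay.

Among these three, compound 3 holds the second highest number. Its nearest neighbour is compound 1, whose value lies within the scatter of its own; compound 2 sits furthest away, with a 2.0-fold higher number from compound 2 to compound 3 (0.31 log units; beyond the scatter).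

Compound 4, `O=C(Nc1cccc([N+](=O)[O-])c1)c1ccc(/N=N\c2c[nH]c3ccccc23)cc1`, has not yet been measured. It differs from compound 3 only at the amide-type nitrogen: 3-nitrophenyl in place of 2-methoxyphenyl on an amide-type nitrogen. Both groups are single six-membered aromatic rings of carbon only; the entering one brings one more heavy atom and one more hydrogen-bond acceptor.

For the measured compounds named here, only one measured step swaps one whole aryl group for another on that nitrogen, and it is modest: a 2.0-fold higher number from compound 2 to compound 3 (0.31 log units; beyond the scatter). The two other steps, a 3.5-fold lower number from compound 1 to compound 2 (0.54 log units; beyond the scatter) and a 1.7-fold lower number from compound 1 to compound 3 (0.23 log units; within the scatter), add a single group to the same ring and are at most modest. Going by the values given here, no measured compound carries a nitro group, so nothing shows how that group behaves here. Taken together, these steps point to a small change for compound 4, in either direction, with a slight lean toward a lower number; the expected step is a 1.2-fold lower number from compound 3 to compound 4 (0.09 log units; within the scatter). Compound 4 is therefore estimated at 70000 nM in this assay, with a likely range from 25000 nM to 200000 nM.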

Compound 4, half-maximal inhibitory concentration: 51900 nM
The estimate for compound 4 lay 1.3-fold (0.13 log units) above the measured number, and the stated range covers the measured number.
By their numbers in this assay, from the lowest: compounds 2, 4, 3 and 1 (each within the scatter of the next, the first and the last beyond it).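

On the amide-type nitrogen, the 3-nitrophenyl group of compound 4 cannot be told apart in this assay from either of the other substituted rings, with a 1.7-fold lower number from compound 3 to compound 4 (0.22 log units; within the scatter) and a 1.2-fold higher number from compound 2 to compound 4 (0.09 log units; within the scatter). Set against the plain phenyl ring, however, the nitro group gives a step beyond the scatter, a 2.8-fold lower number from compound 1 to compound 4 (0.45 log units; beyond the scatter), which joins the methyl step, a 3.5-fold lower number from compound 1 to compound 2 (0.54 log units; beyond the scatter), while the methoxy step goes against this pattern, a 1.7-fold lower number from compound 1 to compound 3 (0.23 log units; within the scatter). The earlier compounds shown here held no nitro group, and compound 4 now shows that this group, so unlike methyl in its atoms, gives a reading within the scatter of the methyl compound.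

Nothing measured here accounts for these readings. For the compounds shown here, still open is whether 2-nitrophenyl or 4-nitrophenyl would read like 3-nitrophenyl, since each substituent appears at only one place on the ring, and whether an amine or a carboxylic acid on this ring would move the number further than any step seen so far.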